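Swapping One Aryl Arm for Another on a Shared Core

The compounds below may be only part of what the source reports. "The series", "measured", "known", "first", "only" and "open" are said of these compounds alone.

Measured so far:
compound 1 `Cc1nc2c3ccccc3ccc2c2nc3c(ccc4ccccc43)c(-c3cc([N+](=O)[O-])ccc3N)c12` gives 93.1 ug/mL in a functional assay, read by spectrophotometry, with a stated time of 30 min; a lower number here means a stronger inhibitor, a higher number a weaker inhibitor
compound 2 `Cc1nc2c3ccccc3ccc2c2nc3c(ccc4ccccc43)c(-c3ccccc3Cl)c12` gives 118 ug/mL in this assay

Compound 2 stands nearest to compound 1, and the step of a 1.3-fold higher number from compound 1 to compound 2 (0.10 log units; within the scatter) lies within the scatter, so the two cannot be told apart. Compound 3 `Cc1ccc(-c2c3ccc4ccccc4c3nc3c2c(C)nc2c4ccccc4ccc32)cc1` differs from compound 2 by 4-methylphenyl in place of 2-chlorophenyl on an aromatic carbon. Going by the values given here, only one measured step bears on this carbon, a 1.3-fold higher number from compound 1 to compound 2 (0.10 log units; within the scatter), and it was within the scatter when one aryl group replaced another there. On that basis no step beyond the scatter is expected in this assay; the expected step of a 1.0-fold lower number from compound 2 to compound 3 (0.01 log units; within the scatter) is small. Compound 3 is therefore estimated at 115 ug/mL, with a range from 55 ug/mL to 240 ug/mL.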

Compound 3, half-maximal inhibitory concentration: 123 ug/mL
Beside the measured number, compound 3's estimate is 1.1-fold (0.03 log units) below it; measured number inside the range.
By their numbers in this assay, from the lowest: compounds 1, 2 and 3 (each within the scatter of the next).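

At this aromatic carbon in this assay, 4-methylphenyl in place of 2-chlorophenyl gives a 1.0-fold higher number from compound 2 to compound 3 (0.02 log units; within the scatter) and 4-methylphenyl in place of 2-amino-5-nitrophenyl gives a 1.3-fold higher number from compound 1 to compound 3 (0.12 log units; within the scatter) as its step. A third aryl group therefore joins the other two, and all three remain within the scatter of one another. No supporting measurement explains why they read alike.

All three groups shown are aryl rings. On these data alone, whether an amine, a carboxylic acid or a longer alkyl chain on this carbon would give a clearly different number remains open.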